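A few compounds are considered here, and "the series" means these few. Any claim that something is new, unique, unknown or untested is made for them only; others in the source may bear on it.

Compound 1 `c1ccc(-c2ccc(OCc3nnc(-c4ccccc4)o3)cc2)cc1`: 18.2%
Compound 2 `Clc1ccc(-c2nnc(COc3ccc(-c4ccccc4)cc3)o2)cc1`: 75%

In a functional assay on the whole organism (strain Wistar) for inhibition, with Rattus norvegicus as the target, read by paw edema, with a stated time of 3 h, at a dose of 10 mg/kg by the oral route (a higher number here means more inhibition at the dose given (going by the name of the read-out), a lower number less inhibition), compound 2 stands highest of the two numbers measured. Among the compounds with values here, the one measured step shows a number 56.8 percentage points higher from compound 1 to compound 2 (beyond the scatter), a large gain from adding chloro in place of hydrogen. Compound 3 `Clc1ccccc1-c1nnc(COc2ccc(-c3ccccc3)cc2)o1` is not yet measured; it differs from compound 2 by 2-chlorophenyl in place of 4-chlorophenyl on an aromatic carbon. Within the data shown here, that single step concerns the presence of chloro, not where the chloro sits, so no measured step bears directly on this change. The expected step is therefore modest and uncertain, a number 20 percentage points lower from compound 2 to compound 3 (beyond the scatter). Compound 3 is estimated at 55%, with a range from 30% to 75%.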

Compound 3, a percentage reported as inhibition, in the whole organism at one dose (the size of the read-out at that dose, not a potency): 59.1%
Beside the measured number, compound 3's estimate is 4.1 percentage points below it; the measured number falls inside the stated range.
By their numbers in this assay, from the lowest: compound 1; then compound 3; then compound 2.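

Within this assay, the place of the chloro matters as well as its presence: 2-chlorophenyl in place of 4-chlorophenyl gives a number 15.9 percentage points lower from compound 2 to compound 3 (beyond the scatter). The gain from chloro in place of hydrogen persists with 2-chlorophenyl, with a number 40.9 percentage points higher from compound 1 to compound 3 (beyond the scatter), so it is not confined to 4-chlorophenyl. Nothing available explains the difference between the two placements. The compounds shown leave open whether a different group on this phenyl, such as a methoxy or an amine, would match compound 2.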